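Compound 3 to compound 4: a change of configuration only

The source may hold more compounds than are shown below. What is called first, only, known or untested is meant among the compounds shown, and "the series" means these compounds.

Values in a physicochemical assay for lipophilicity, using the shake flask method, in phosphate buffer, measured as octanol-water partition, at pH 7.4 (a lower number here means a more polar compound, a higher number a more lipophilic compound), so far:
- compound 1 `CC(=O)N1CC(CC#N)(n2cc(-c3nc(-c4cnn(C)c4)cn4nccc34)cn2)C1` gives 1.2
- compound 2 `CCN1CC(CC#N)(n2cc(-c3nc(-c4cnn(C)c4)cn4nccc34)cn2)C1` gives 2.1
- compound 3 `Cn1ccc(-c2cn3nccc3c(-c3cnn([C@]4(CC#N)C[C@@H](C#N)C4)c3)n2)n1` gives 1.6

Compound 3 stands second highest of the three, with compound 1 lower and compound 2 higher, and both gaps lie beyond the usual scatter. Compound 4 `Cn1ccc(-c2cn3nccc3c(-c3cnn([C@]4(CC#N)C[C@H](C#N)C4)c3)n2)n1` still awaits measurement. Its relation to compound 3 is the two compounds have the same atoms and bonds and differ only in configuration as drawn: 2 of 2 stereo elements differ (all stereocentres are inverted: mirror images); a stereocentre at a saturated ring carbon is drawn r in compound 3 and s in compound 4; a stereocentre at a saturated ring carbon is drawn r in compound 3 and s in compound 4. Nothing leaves and nothing enters.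

Within the data shown here, the only measured step is a number 0.90 log units higher from compound 1 to compound 2 (beyond the scatter). That step puts ethyl in place of acetyl on an amine nitrogen in a ring, so it changes the atoms and offers no direct guide to its size here. Among the measured compounds shown here, no measured pair differs only in configuration as drawn, and the data therefore give no direction for this change. With the same atoms and bonds on both sides, no step beyond the scatter is expected in this assay. The expectation rests on compound 3 at 1.6 as the starting point. The estimated step is no change at the digits printed from compound 3 to compound 4 (within the scatter) and it is expected to stay within the scatter. For compound 4 the estimated value is 1.6 with an expected range from 1.3 to 1.9 as its limits.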

Compound 4, distribution coefficient: 1.6
Estimate against measurement, compound 4: no gap at the digits printed; measured number inside the range.
By their numbers in this assay, from the lowest: compound 1; then compounds 3 and 4 (each within the scatter of the next); then compound 2.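

In this assay, inverting both stereocentres at the saturated ring carbons gives no change at the digits printed from compound 3 to compound 4 (within the scatter). Among these compounds, this is the first measured pair that differs only in configuration as drawn. Among the compounds shown here, the one earlier step, a number 0.90 log units higher from compound 1 to compound 2 (beyond the scatter), changes the atoms on an amine nitrogen in a ring, whereas here nothing leaves and nothing enters, which isolates configuration at these two stereocentres and shows no step beyond the scatter in this read-out. The reading holds for this pair alone, and the matching numbers go with the relation between its two members: the fact that compounds 3 and 4 differ only in the configuration as drawn.

Open, as far as these compounds go, is whether a carboxylic acid or a longer chain in place of the nitrile at this ring carbon would keep two compounds of opposite configuration within the scatter of each other in this assay. Also open is whether compound 3 and compound 4 read alike in any measurement outside this assay, as the compounds shown give one read-out only.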